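A few compounds are considered here, and "the series" means these few. Any claim that something is new, unique, unknown or untested is made for them only; others in the source may bear on it.

Measured so far, in a functional assay on MCF7 cells (Homo sapiens) for antiproliferative activity; on this read-out lower numbers stand for stronger inhibition and higher numbers for weaker inhibition:
compound 1 `COc1cc(Cc2nc3c(N)nc(F)nc3n2CC2CCCO2)cc(OC)c1OC` gives 22900 nM
compound 2 `CCCCCn1c(Cc2cc(OC)c(OC)c(OC)c2)nc2c(N)nc(F)nc21` gives 36300 nM
compound 3 `CC[C@H](C)Cn1c(Cc2cc(OC)c(OC)c(OC)c2)nc2c(N)nc(F)nc21` gives 43700 nM

Compound 3 carries the highest of the three numbers, yet none of the three stands apart from the others: a 1.9-fold higher number from compound 1 to compound 3 (0.28 log units; within the scatter), a 1.2-fold higher number from compound 2 to compound 3 (0.08 log units; within the scatter), and a 1.6-fold higher number from compound 1 to compound 2 (0.20 log units; within the scatter) all sit within the scatter. Compound 4 `C#CCCn1c(Cc2cc(OC)c(OC)c(OC)c2)nc2c(N)nc(F)nc21` keeps the shared core and differs from compound 3 in one place: propargyl in place of sec-butyl on a saturated chain carbon bound to an aromatic nitrogen. All three measured steps exchange one chain for another at this same carbon, and none of them moved the number beyond the scatter. A further exchange of this kind is therefore expected to leave this assay essentially unchanged. For compound 4 the estimate is 40000 nM, with a range of 15000 nM to 100000 nM. The implied step, a 1.1-fold lower number from compound 3 to compound 4 (0.04 log units; within the scatter), is expected to stay within the scatter.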

Compound 4, half-maximal inhibitory concentration: 25100 nM
Beside the measured number, compound 4's estimate is 1.6-fold (0.20 log units) above it; low and high end bracket the measured number.
By their numbers in this assay, from the lowest: compounds 1, 4, 2 and 3 (each within the scatter of the next).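

In this assay the propargyl chain, the first here with a triple bond outside aromatic rings, stays level with the other three compounds: a 1.7-fold lower number from compound 3 to compound 4 (0.24 log units; within the scatter) and a 1.4-fold lower number from compound 2 to compound 4 (0.16 log units; within the scatter) and a 1.1-fold higher number from compound 1 to compound 4 (0.04 log units; within the scatter). Open-chain, ring-bearing and triple-bonded groups on this saturated chain carbon bound to an aromatic nitrogen therefore all remain within the scatter of one another. No supporting information bears on this flat response.

Going by these compounds, whether an amine, a carboxylic acid or a longer chain at this carbon would move the number beyond the scatter remains open.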